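The source may report more compounds than this note shows. Statements on the series, on what has been measured and on what is new or still open speak of the compounds shown alone.

Measured so far in an assay on CHO cells for antagonist activity at transient receptor potential cation channel subfamily V member 1 (Homo sapiens), read by FLIPR; on this read-out lower numbers stand for stronger inhibition and higher numbers for weaker inhibition:
- compound 1 `CS(=O)(=O)Nc1ccc(C(C(=O)NCc2ccc(C(F)(F)F)nc2SC2CCCCC2)C2CCCC2)cc1F` gives 103 nM
- compound 2 `CC1CCN(c2nc(C(F)(F)F)ccc2CNC(=O)C(c2ccc(F)cc2)c2ccc(NS(C)(=O)=O)c(F)c2)CC1` gives 3.4 nM
- compound 3 `CS(=O)(=O)Nc1ccc(C(C(=O)NCc2ccc(C(F)(F)F)nc2SC2CCCCC2)c2ccc(F)cc2)cc1F` gives 37.6 nM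

Compound 2 stands lowest of the three, with compound 3 nearest, as an 11-fold higher number from compound 2 to compound 3 (1.04 log units; beyond the scatter) shows, and compound 1 furthest. Compound 4 `Cc1ccc(CC(C(=O)NCc2ccc(C(F)(F)F)nc2N2CCC(C)CC2)c2ccc(NS(C)(=O)=O)c(F)c2)cc1` differs from compound 2 by 4-methylbenzyl in place of 4-fluorophenyl on a saturated chain carbon bound to an aromatic carbon and a carbonyl carbon. Going by the values given here, the only measured step at this place is a 2.7-fold lower number from compound 1 to compound 3 (0.44 log units; beyond the scatter), a modest fall when 4-fluorophenyl entered in place of cyclopentyl. Here 4-fluorophenyl leaves, so a modest rise in this assay beyond the scatter is expected for compound 4, though no step with 4-methylbenzyl exists to fix its size. Compound 4 is therefore estimated at 9 nM, between 3 nM and 28 nM, meaning an expected step of a 2.6-fold higher number from compound 2 to compound 4 (0.42 log units; beyond the scatter).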

Compound 4, inhibition constant: "active" (no number reported)
No number was reported for compound 4; the estimate stays without a comparison.
By their numbers in this assay, from the lowest: compound 2; then compound 3; then compound 1.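

Going by these compounds alone, compound 4 carries only the label "active", so no step from compound 2 to compound 4 can be read, and no evidence bears on this result. On these data alone, the size of the change with 4-methylbenzyl in place of 4-fluorophenyl stays open.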